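The compounds below may be only part of what the source reports. "The series", "measured", "known", "first", "only" and "open" are said of these compounds alone.

Measured so far in an assay on isolated protein for inhibition of Amine oxidase [flavin-containing] B (Homo sapiens), read by Amplex Red, with a stated time of 15 min; on this read-out higher numbers stand for weaker inhibition and lower numbers for stronger inhibition:
Compound 1 `CC(=O)c1ccc(OCc2cccc(C)c2)cc1`: 86.3 nM
Compound 2 `CC(=O)c1ccc(OCc2cccc(Br)c2)cc1`: 214 nM
Compound 3 `CC(=O)c1cccc(OCc2cccc(Br)c2)c1`: 96.3 nM

Compounds 1 and 2 share one core and differ only by methyl in place of bromo on an aromatic carbon; this change gave a 2.5-fold lower number from compound 2 to compound 1 (0.39 log units; beyond the scatter). Compound 3 has the same atoms as compound 2 joined differently; the difference between the two cores is not broken down here. Compound 4 `CC(=O)c1cccc(OCc2cccc(C)c2)c1`, not yet measured, stands to compound 3 as compound 1 stands to compound 2, differing by methyl in place of bromo on an aromatic carbon, the same change at the same kind of place.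

If the change carries over to the core of compound 3, a step like the one seen from compound 2 to compound 1 is expected, giving a 2.4-fold lower number from compound 3 to compound 4 (0.38 log units; beyond the scatter) in this assay. This rests on a single pair, so the estimate is held loosely. Compound 4 is expected at 40 nM, between 20 nM and 85 nM.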

Compound 4, half-maximal inhibitory concentration: 893 nM
For compound 4 the middle estimate is 22-fold (1.35 log units) below the measured one, and the stated range ends below it.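

On the core of compound 3, methyl in place of bromo gave a 9.3-fold higher number from compound 3 to compound 4 (0.97 log units; beyond the scatter) in this assay and so ran opposite to the step seen on the other core. Set side by side, the two steps differ clearly: the same change on two cores in this assay, a 2.5-fold lower number (0.39 log units; beyond the scatter) from compound 2 to compound 1 and a 9.3-fold higher number (0.97 log units; beyond the scatter) from compound 3 to compound 4, 23-fold (1.36 log units) apart, beyond the scatter of two such steps. This shows that in these two pairs the effect of the change depends on the core, so a step read on one core could not be carried to the other, but it does not show what in the cores causes the split, and two pairs give no rule for further cores. As far as these compounds go, whether other groups in the same place, such as chloro, methoxy or an amine, would part the two cores in the same way remains open.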